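This account rests on a few compounds, and the source may have more. Where it says the series, first, only, none or still open, it means among the compounds named here.

- Compound 1 `C=C1C(=O)[C@@]23C(=O)OC[C@]4([C@@H](OC(C)=O)CCC(C)(C)[C@H]4C=O)[C@@H]2CC[C@@H]1[C@H]3O`: 75400 nM
- Compound 2 `C=C1C(=O)[C@@]23C(=O)OC[C@]4(C(=O)CCC(C)(C)[C@H]4C=O)[C@@H]2CC[C@@H]1[C@H]3OC(=O)CC`: 1650 nM

These two compounds were tested in a functional assay on Bel-7402 cells (Homo sapiens) for cytotoxicity, read by MTT assay, with a stated time of 72 h; a higher number here means a weaker inhibitor, a lower number a stronger inhibitor. Compound 2, at 1650 nM, holds the lower of the two numbers and is therefore the stronger inhibitor. The gap to compound 1, at 75400 nM, lies well beyond the scatter. The two compounds differ in more than one place, so their gap does not show what any single change does.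

Compound 3 `C=C1C(=O)[C@@]23C(=O)OC[C@]4(C(=O)CCC(C)(C)[C@H]4C=O)[C@@H]2CC[C@@H]1[C@H]3OC(=O)c1ccc(C(F)(F)F)cc1` keeps the rest of compound 2 but carries 4-(trifluoromethyl)phenyl in place of ethyl on a carbonyl carbon. Within the data shown here, no measured pair here tests a change at this place, so the expectation is cautious, with no step beyond the scatter in either direction. The expected step is a 1.2-fold lower number from compound 2 to compound 3 (0.07 log units; within the scatter). For compound 3 the estimated value is 1400 nM, with an expected range of 350 nM to 5600 nM.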

Compound 3, half-maximal inhibitory concentration: 3990 nM
The estimate for compound 3 lay 2.9-fold (0.45 log units) below the measured number; low and high end bracket the measured number.
By their numbers in this assay, from the lowest: compound 2; then compound 3; then compound 1.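

Among these compounds, this is the first pair that differs in only one place, so the effect of this change can be read on its own: in this assay, exchanging ethyl for 4-(trifluoromethyl)phenyl on the carbonyl carbon gives a 2.4-fold higher number from compound 2 to compound 3 (0.38 log units; beyond the scatter). The step is modest even though the entering group is much larger and brings an aromatic ring, so this place accepts a large change of group with only a limited shift in the number. Nothing available explains the direction of the step.

The compounds shown leave open whether the step comes from the ring itself or from the trifluoromethyl group it carries, which a plain phenyl would help to separate. Also open, on these data alone, is how a longer straight chain or a chain bearing an amine would compare with ethyl here.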